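Aryl sulfonamide swap on a lactone triazole scaffold

The compounds below may be only part of what the source reports. "The series", "measured", "known", "first", "only" and "open" are said of these compounds alone.

Of the compounds shown here, three sharing one core have been measured in a functional assay on HepG2 cells (Homo sapiens) for antiproliferative activity, read by MTT assay, with a stated time of 72 h; on this read-out lower numbers stand for stronger inhibition and higher numbers for weaker inhibition. Compound 1 `CC(C)(C)c1cn(C[C@H](O)[C@H]2OC(=O)C(OCc3ccccc3)=C2OCc2ccccc2)nn1` gives 29200 nM. Compound 2 `Cc1ccc(S(=O)(=O)NCc2cn(C[C@H](O)[C@H]3OC(=O)C(OCc4ccccc4)=C3OCc3ccccc3)nn2)cc1` gives 24900 nM, the lowest of the three numbers, though its step to compound 1 is within the scatter. Compound 3 `O=C1O[C@H]([C@@H](O)Cn2cc(-c3cccc(O)c3)nn2)C(OCc2ccccc2)=C1OCc1ccccc1` gives 62700 nM. The steps were a 1.2-fold lower number from compound 1 to compound 2 (0.07 log units; within the scatter), a 2.1-fold higher number from compound 1 to compound 3 (0.33 log units; beyond the scatter) and a 2.5-fold higher number from compound 2 to compound 3 (0.40 log units; beyond the scatter).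

Compound 4 `O=C1O[C@H]([C@@H](O)Cn2cc(CNS(=O)(=O)c3ccc(Cl)cc3F)nn2)C(OCc2ccccc2)=C1OCc1ccccc1` is not yet measured. It differs from compound 2 by 4-chloro-2-fluorophenyl in place of 4-methylphenyl on a sulfonyl sulfur. Going by the values given here, none of the measured steps changes this sulfonyl aryl group; the closest is the step from compound 1 to compound 2, in which the whole (((4-methylphenyl)sulfonyl)amino)methyl group entered, with a 1.2-fold lower number from compound 1 to compound 2 (0.07 log units; within the scatter), a change within the scatter. With only that to go on, no step beyond the scatter is expected for compound 4 in this assay . Compound 4 is therefore estimated at 22000 nM, within a range from 9000 nM to 55000 nM, which means an expected step of a 1.1-fold lower number from compound 2 to compound 4 (0.05 log units; within the scatter).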

Compound 4, half-maximal inhibitory concentration: 25500 nM
Estimate against measurement, compound 4: 1.2-fold (0.06 log units) below, within the range that was stated.
By their numbers in this assay, from the lowest: compounds 2, 4 and 1 (each within the scatter of the next); then compound 3.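

Putting 4-chloro-2-fluorophenyl in place of 4-methylphenyl on the sulfonyl sulfur gives a 1.0-fold higher number from compound 2 to compound 4 (0.01 log units; within the scatter) in this assay and is the only step shown that alters this aryl group directly. The earlier compounds shown here showed only the entire (((4-methylphenyl)sulfonyl)amino)methyl group replacing or being replaced by another group, whereas this pair shows that the aryl group can take chlorine and fluorine in these places without a readable change in this assay. Nothing measured here offers an explanation for this result.

The compounds shown leave open whether this insensitivity holds for other groups on the sulfonyl sulfur, such as a simple methyl, or for an aryl ring carrying an amine or a carboxylic acid. They also leave open whether an amide in place of the sulfonamide would move the number.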